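Methylsulfanyl for iodo on the thiourea aryl ring

The source may hold more compounds than are shown below. What is called first, only, known or untested is meant among the compounds shown, and "the series" means these compounds.

Compound 1, `N#Cc1ccccc1CN1CCc2c(sc(NC(=O)c3ccccc3Cl)c2C(N)=O)C1`: > 50000 nM
Compound 2, `NC(=O)c1c(NC(=O)c2ccccc2Cl)sc2c1CCN(Cc1ccc([N+](=O)[O-])cc1)C2`: 46100 nM
Compound 3, `NC(=O)c1c(NC(=O)c2ccccc2Cl)sc2c1CCN(C(=S)Nc1ccccc1I)C2`: 29000 nM

In a functional assay on HeLa cells (Homo sapiens) for antiproliferative activity, with a stated time of 24 h (a higher number here means a weaker inhibitor, a lower number a stronger inhibitor), compound 1 reaches only the limit of the assay, > 50000 nM, and gives no number. Compound 2 gives 46100 nM in this assay. Compound 3 gives 29000 nM and so holds the lowest of the two numbers shown, though the step of a 1.6-fold lower number from compound 2 to compound 3 (0.20 log units; within the scatter) stays within the scatter. The two steps from compound 1 are floors only, an at least 1.0-fold lower number from compound 1 to compound 2 (0.03 log units; that floor lies within the scatter) and an at least 1.7-fold lower number from compound 1 to compound 3 (0.23 log units; that floor lies within the scatter), both set by the limit of > 50000 nM in this assay, at which 1 of the 3 values shown sits.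

Compound 4 is `CSc1ccccc1NC(=S)N1CCc2c(sc(NC(=O)c3ccccc3Cl)c2C(N)=O)C1`. It differs from compound 3 by methylsulfanyl in place of iodo on an aromatic carbon, ortho to a large group. No measured step touches this ring position; the steps shown all change the whole group on the amine nitrogen in the ring, and the one numbered step among them lies within the scatter. Compound 4 is therefore expected to sit near compound 3, with a step of a 1.0-fold higher number from compound 3 to compound 4 (0.01 log units; within the scatter) in this assay. The estimate for compound 4 is 30000 nM, in a range from 10000 nM to 60000 nM.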

Compound 4, half-maximal inhibitory concentration: 43600 nM
Beside the measured number, compound 4's estimate is 1.5-fold (0.16 log units) below it; measured number inside the range.
By their numbers in this assay, from the lowest: compounds 3, 4 and 2 (each within the scatter of the next). At a limit, above all of these: compound 1.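

Among these compounds, compound 4 gives the first reading of a change on the thiourea aryl ring itself, with the rest of the molecule held fixed. Methylsulfanyl in place of iodo on this aromatic carbon, ortho to a large group, gives a 1.5-fold higher number from compound 3 to compound 4 (0.18 log units; within the scatter) in this assay, so the two groups cannot be told apart here, despite the difference in their atoms. The step of a 1.1-fold lower number from compound 2 to compound 4 (0.02 log units; within the scatter) also leaves compound 4 unseparated from the 4-nitrophenyl compound, and the step of an at least 1.1-fold lower number from compound 1 to compound 4 (0.05 log units; that floor lies within the scatter) can be read only as a floor, because it is set by a limit: the limit of > 50000 nM in this assay, at which 1 of the 4 values shown sits.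

As far as these compounds go, it remains open whether an amine or a carboxylic acid on this aromatic carbon would move the number beyond the scatter. Also open, from the compounds shown here alone, is what a urea in place of the thiourea would do with either aryl group.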